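The source may hold more compounds than are shown below. What is called first, only, known or untested is meant among the compounds shown, and "the series" means these compounds.

Measured compounds in an assay on HEK293 cells for inhibition of kynurenine 3-monooxygenase (Homo sapiens), read by LC-MS, with a stated time of 20 h; on this read-out lower numbers stand for stronger inhibition and higher numbers for weaker inhibition: compound 1 `C[C@@H](Oc1cc2oc(=O)n(CCC(=O)O)c2cc1Cl)c1ccc(F)cn1` gives 25.1 nM; compound 2 `Cc1ccc([C@@H](C)Oc2cc3oc(=O)n(CCC(=O)O)c3cc2Cl)nc1` gives 6.31 nM; compound 3 `O=C(O)CCn1c(=O)oc2cc(OCC3CCC3)c(Cl)cc21` gives 1260 nM.

Compound 3 stands at the highest number of the three, well beyond the scatter from both others: compound 1 sits at the nearer value and compound 2 at the further one. For the measured compounds named here, compound 3 carries a cyclobutylmethoxy group where compounds 1 and 2 carry aryl-substituted ethoxy groups; no single-point step connects them, so only the bare values can be set side by side.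

Compound 4 `CC(C)Cc1cc2oc(=O)n(CCC(=O)O)c2cc1Cl` is not yet measured. It differs from compound 3 by isobutyl in place of cyclobutylmethoxy on an aromatic carbon. Going by the values given here, the only measured step, a 4.0-fold lower number from compound 1 to compound 2 (0.60 log units; beyond the scatter), concerns an exchange of two small substituents on the distal aromatic ring and does not touch the ether oxygen or the ring-to-chain exchange at hand. Among the compounds with values here, no measured step therefore bears directly on this change, and the expectation rests on compound 3 alone, already the weakest measured value, with wide uncertainty. Compound 4 is expected at 3000 nM, with a range from 800 nM to 12000 nM. The expected step is a 2.4-fold higher number from compound 3 to compound 4 (0.38 log units; beyond the scatter), toward weaker inhibition but not confidently beyond the scatter.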

Compound 4, half-maximal inhibitory concentration: 794 nM
The estimate for compound 4 lay 3.8-fold (0.58 log units) above the measured number, and the stated range ends above it.
By their numbers in this assay, from the lowest: compound 2; then compound 1; then compounds 4 and 3 (each within the scatter of the next).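

In this assay, isobutyl in place of cyclobutylmethoxy on this aromatic carbon, ortho to a chloro group, gives a 1.6-fold lower number from compound 3 to compound 4 (0.20 log units; within the scatter), so the two values stay within the scatter of each other. For the compounds shown here, this is the first measured exchange at this position, and it shows that the oxygen and the four-membered ring can leave in a single step without a difference beyond the scatter, with the group shrinking from cyclobutylmethoxy to isobutyl. Nothing available explains why the two compounds read alike.

The step removes the oxygen and the ring together, so this pair does not separate one from the other. From the compounds shown here alone, how an amine or a straight hexyl chain on this aromatic carbon would read in this assay stays open.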